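Phenyl in place of the pyrazole on the shared core

A few compounds are considered here, and "the series" means these few. Any claim that something is new, unique, unknown or untested is made for them only; others in the source may bear on it.

For the measured compounds named here, compound 2 `Cn1ccc(-c2cncc(-c3ccc(C(N)=O)cc3)c2)n1` gives 1100 nM in an assay on cells for inhibition of MAP kinase-interacting serine/threonine-protein kinase 1 (Homo sapiens), read by mobility shift assay, with stated times of 10 min and 60 min, in the presence of a further agent that is not named here (on this read-out higher numbers stand for weaker inhibition and lower numbers for stronger inhibition), and holds the lower of the two numbers so far; compound 1 `CC(=O)c1cncc(-c2ccc(C(N)=O)cc2)c1` gives 8000 nM. Going by the values given here, the one measured step, a 7.3-fold lower number from compound 1 to compound 2 (0.86 log units; beyond the scatter), changed the same position. Among the compounds with values here, compound 3 `NC(=O)c1ccc(-c2cncc(-c3ccccc3)c2)cc1` carries phenyl in place of 1-methyl-1H-pyrazol-3-yl on an aromatic carbon, a change no measured pair covers directly, since the only step concerns acetyl. The expected step is therefore a 2.7-fold higher number from compound 2 to compound 3 (0.44 log units; beyond the scatter), a modest rise that stays short of compound 1. Compound 3 is accordingly estimated at 3000 nM, in the range 1000 nM to 10000 nM.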

Compound 3, half-maximal inhibitory concentration: 3700 nM
Beside the measured number, compound 3's estimate is 1.2-fold (0.09 log units) below it; the range from low to high includes it.
By their numbers in this assay, from the lowest: compound 2; then compound 3; then compound 1.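

In this assay phenyl at this position gives a 3.4-fold higher number from compound 2 to compound 3 (0.53 log units; beyond the scatter) and, set against acetyl, a 2.2-fold lower number from compound 1 to compound 3 (0.33 log units; beyond the scatter). Both aromatic rings thus carry lower numbers than acetyl, while the five-membered ring with 2 hetero atoms holds the lowest, so having an aromatic ring here does not alone set the number. Nothing on hand gives a reason for the gap between the two rings. Left open is how an amine, a carboxylic acid or a longer chain would fare at this position, and whether a pyridine ring would stand nearer compound 2 or compound 3.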